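This account rests on a few compounds, and the source may have more. Where it says the series, first, only, none or still open, it means among the compounds named here.

In an ADME assay on MRC5 cells (Homo sapiens) for cytotoxicity, read by fluorescence, with a stated time of 72 h (a lower number here means a stronger inhibitor, a higher number a weaker inhibitor), compound 1 `CC1(COc2ccc(OC(F)(F)F)cc2)Cn2cc([N+](=O)[O-])nc2O1` gives > 64000 nM, a limit and not a number. Compound 2 `C[C@@]1(COc2ccc(OC(F)(F)F)cc2)Cn2cc([N+](=O)[O-])nc2O1` gives > 64000 nM, also a limit. Compound 3 `CC1(COc2ccc(Oc3ccccc3)cc2)Cn2cc([N+](=O)[O-])nc2O1` gives > 64000 nM, again a limit. All three values sit at the limit of > 64000 nM in this assay, at which 3 of the 3 values shown sit, so compound 1 has no readable position in the series. Compound 4 `CC1(COc2ccc(OC(F)(F)F)cc2)Cn2cc(S(C)(=O)=O)nc2O1` carries methylsulfonyl in place of nitro on an aromatic carbon. Neither measured change touches that place, and neither a step that the two limits leave unreadable from compound 1 to compound 2 nor a step that the two limits leave unreadable from compound 1 to compound 3 has a readable size. Compound 1 stands at > 64000 nM, a limit, so no step beyond the scatter is expected in this assay, and another limit is the likely result. The estimated step is a number no higher from compound 1 to compound 4 (the limit leaves the size open). Compound 4 is estimated at 64000 nM, with an expected range from 30000 nM to 128000 nM.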

Compound 4, half-maximal inhibitory concentration: > 64000 nM
Compound 4 ended at the assay's limit; the forecaster's own chance of this, stated with the estimate: 80%; the middle value lies on the limit itself.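

In this assay, compound 1 and compound 4 both end at a limit, so no step between them can be read: the limit of > 64000 nM in this assay, at which 4 of the 4 values shown sit.

The compounds shown leave open whether methylsulfonyl in place of nitro, or any other change among them, shifts this assay at all.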